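Swapping the ether-linked ring for a thioether-linked phenyl

The source may report more compounds than this note shows. Statements on the series, on what has been measured and on what is new or still open speak of the compounds shown alone.

Measured so far:
- compound 1 `O=C(COCc1cccnc1)N1CCN(c2ccc(Cl)cc2Cl)CC1`: 1090 nM
- compound 2 `O=C(COCc1cnccn1)N1CCN(c2ccc(Cl)cc2Cl)CC1`: 5200 nM
- compound 3 `O=C(COCc1nccs1)N1CCN(c2ccc(Cl)cc2Cl)CC1`: 10300 nM

All three share the same core and differ only in the aromatic ring hanging off the ether chain. In a functional assay on HEK293 cells for positive allosteric modulation of metabotropic glutamate receptor 5 (Homo sapiens), read by FLIPR and calcium flux (on this read-out lower numbers stand for an effect already at smaller amounts and higher numbers for an effect only at larger amounts of compound), compound 3 gives the highest number of the three. Its nearest neighbour is compound 2, and a 2.0-fold higher number from compound 2 to compound 3 (0.30 log units; within the scatter) lies within the scatter, so the two cannot be ordered. The step of a 9.4-fold higher number from compound 1 to compound 3 (0.98 log units; beyond the scatter) is beyond the scatter, as is a 4.8-fold higher number from compound 1 to compound 2 (0.68 log units; beyond the scatter).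

Compound 4 `O=C(CSc1ccccc1)N1CCN(c2ccc(Cl)cc2Cl)CC1` is not yet measured. Its difference from compound 3 is phenylsulfanyl in place of (1,3-thiazol-2-yl)methoxy on a saturated chain carbon bound to a carbonyl carbon. Among the measured compounds shown here, none of the measured steps covers this exact change: each of them swaps one ring for another while keeping the ether chain, whereas here both the ring and the chain change. What the measured steps do show is that compound 3 sits at the unfavourable end of the three, so a move away from it is, if anything, more likely to give a lower number than a higher one. A modest step in that direction, a 4.1-fold lower number from compound 3 to compound 4 (0.61 log units; beyond the scatter), is expected, with wide uncertainty. For compound 4 the estimate is 2500 nM, between 500 nM and 12000 nM.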

Compound 4, half-maximal effective concentration: > 25000 nM
Compound 4 was reported as a limit (the forecaster's own chance of this, stated with the estimate: 10%); middle value at least 10-fold (1.00 log units) away from the limit.
By their numbers in this assay, from the lowest: compound 1; then compounds 2 and 3 (each within the scatter of the next). At a limit, above all of these: compound 4.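

In this assay compound 4 is reported only as a limit, not as a number: the limit of > 25000 nM in this assay, at which 1 of the 4 values shown sits. This change gives an at least 2.4-fold higher number from compound 3 to compound 4 (0.38 log units; beyond the scatter), and measured against the other two ether compounds it gives an at least 4.8-fold higher number from compound 2 to compound 4 (0.68 log units; beyond the scatter) and an at least 22-fold higher number from compound 1 to compound 4 (1.36 log units; beyond the scatter), the last of these large. So the ring swaps that kept the ether chain all left a measured number, whereas phenylsulfanyl on the saturated chain carbon bound to a carbonyl carbon, a group that replaces both the ring and the chain, takes the read-out to the limit of the assay, which shows that this position does not accept every group of the same heavy-atom count.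

The compounds shown leave open whether the phenyl ring, the sulfur link or the shorter distance to the ring accounts for this, since all of these change together in compound 4. A phenylmethoxy group would test the ring with the ether chain kept, and a (pyridin-3-yl)methylsulfanyl group would test the sulfur with the ring of compound 1 kept.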